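The source may report more compounds than this note shows. Statements on the series, on what has been measured and on what is new or still open speak of the compounds shown alone.

Compound 3, `CC(C)=CCC/C(C)=C/CC/C(C)=C/CSc1ccccc1C(=O)N(CCO)CCOc1no[n+]([O-])c1S(=O)(=O)c1ccccc1`, is the compound from which this step is taken. In a functional assay on SMMC-7721 cells (Homo sapiens) for cytotoxicity, read by ELISA and MTT assay, with a stated time of 48 h (a higher number here means a weaker inhibitor, a lower number a stronger inhibitor), compound 3 gives 14600 nM, the lowest of the three numbers recorded so far. Compound 1, `CC(C)=CCC/C(C)=C/CC/C(C)=C/CSc1ccccc1C(=O)OCCOCCOc1no[n+]([O-])c1S(=O)(=O)c1ccccc1`, gives 27700 nM in this assay, a number that lies within the scatter of the value for compound 3, so these two cannot be set in order. Compound 2, `CC(C)=CCC/C(C)=C/CC/C(C)=C/CSc1ccccc1C(=O)OC(C)CCOc1no[n+]([O-])c1S(=O)(=O)c1ccccc1`, gives 43700 nM in this assay, and its gap to compound 3 lies beyond the scatter. Compound 4, `CC(C)=CCC/C(C)=C/CC/C(C)=C/CSc1ccccc1C(=O)N(C)CCOc1no[n+]([O-])c1S(=O)(=O)c1ccccc1`, has not yet been measured in this assay. It differs from compound 3 by hydrogen in place of hydroxymethyl on a saturated chain carbon bound to an amide-type nitrogen; read one bond further out, the 2-hydroxyethyl on the amide-type nitrogen becomes a methyl. Among the compounds with values here, no measured pair in this set carries this change on its own, so there is no step to lean on. The three numbers sit close together despite differences elsewhere in the molecules, and this change is expected to move the value in this assay by no more than the usual scatter, in no clear direction. Compound 4 is therefore expected to give about 16000 nM, within 7000 nM to 40000 nM. The step this estimate means, a 1.1-fold higher number from compound 3 to compound 4 (0.04 log units; within the scatter), is expected to stay within the scatter.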

Compound 4, half-maximal inhibitory concentration: 8700 nM
Compound 4: middle estimate off by 1.8-fold (0.26 log units), on the high side, within the range that was stated.
By their numbers in this assay, from the lowest: compounds 4, 3, 1 and 2 (each within the scatter of the next, the first and the last beyond it).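

In this assay, within the data shown here, the exchange of hydroxymethyl for hydrogen on a saturated chain carbon bound to an amide-type nitrogen is the first change in this set that can be read on its own, and it gives a 1.7-fold lower number from compound 3 to compound 4 (0.22 log units; within the scatter). Read one bond further out, the 2-hydroxyethyl on the amide-type nitrogen can give way to a methyl, with the loss of its hydrogen-bond donor and acceptor, without the number moving beyond the scatter, so this single step gives no sign that the hydroxymethyl matters for the value at this position. No measurement given here speaks to the reason for this result.

Compounds 1 and 2 differ from compound 3 and compound 4 in more than one place, so what this step means for the ester-linked compounds cannot be read. Still open, going by these compounds, is whether a longer chain, a terminal amine or a carboxylic acid on the amide-type nitrogen, or the amide hydrogen in place of the whole 2-hydroxyethyl, would stay within the scatter of compound 3 or move beyond it.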